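A few compounds are considered here, and "the series" means these few. Any claim that something is new, unique, unknown or untested is made for them only; others in the source may bear on it.

Measured compounds in an ADME assay on MT2 cells (Homo sapiens) for cytotoxicity, read by XTT assay; a higher number here means that more compound is tolerated, a lower number that less compound is tolerated:

- compound 1, `CC(=O)OC[C@@H]1[C@@]2(C)CC[C@H](Br)C(C)(C)[C@H]2CC[C@]1(C)O`: 70000 nM
- compound 2, `CC(=O)OC[C@@H]1[C@@]2(C)CC[C@H](Br)C(C)(C)[C@@H]2CC[C@@]1(C)O`: 40000 nM
- compound 3, `CC(=O)OC[C@H]1[C@@]2(C)CC[C@H](Br)C(C)(C)[C@@H]2CC[C@@]1(C)O`: 90000 nM

Compound 3 gives the highest of the three numbers in this assay. Its nearest neighbour is compound 1, and a 1.3-fold higher number from compound 1 to compound 3 (0.11 log units; within the scatter); its furthest is compound 2, and a 2.3-fold higher number from compound 2 to compound 3 (0.35 log units; beyond the scatter). The three measured compounds share every atom and bond, and each pair differs only in the configuration as drawn (the fact that compounds 1 and 2 differ only in the configuration as drawn, (the fact that compounds 1 and 3 differ only in the configuration as drawn), (the fact that compounds 2 and 3 differ only in the configuration as drawn)). The remaining measured step, a 1.8-fold lower number from compound 1 to compound 2 (0.24 log units; within the scatter), is likewise small.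

Compound 4, `CC1(C)[C@@H](Br)CC[C@@]2(C)[C@H]1CC[C@@](C)(O)[C@H]2CO`, is to be measured in this assay. It differs from compound 3 by hydrogen in place of acetyl on an oxygen on a saturated carbon. Within the data shown here, none of the measured steps concerns this change: all three concern configuration only, and all are small. Among the measured compounds shown here, no measured step therefore points to a shift in either direction, and a step within the scatter is expected, so that no change at the digits printed from compound 3 to compound 4 (within the scatter) is the estimated change. Compound 4 is accordingly expected to give 90000 nM in this assay, within a range from 40000 nM to 200000 nM.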

Compound 4, half-maximal cytotoxic concentration: 90000 nM
Beside the measured number, compound 4's estimate shows no gap at the digits printed; the range from low to high includes it.
By their numbers in this assay, from the lowest: compounds 2, 1, 3 and 4 (each within the scatter of the next, the first and the last beyond it).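

In this assay, the swap of acetyl for hydrogen on an oxygen on a saturated carbon, which turns acetoxymethyl into hydroxymethyl, gives no change at the digits printed from compound 3 to compound 4 (within the scatter). This is the first step among the compounds shown that alters atoms at this position rather than configuration alone, and it shows that, in the configuration of compound 3, the acetyl can leave without a measurable shift in the number. Nothing in hand bears on why the number stays in place.

The compounds shown leave open whether the same swap would read alike in the configurations of compound 1 and compound 2. They also leave open how the number would respond to a methyl ether or a benzoyl ester on this oxygen, or to an amine in its place.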